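The source may report more compounds than this note shows. Statements on the series, on what has been measured and on what is new or still open speak of the compounds shown alone.

Measured so far:
- compound 1 `COc1cc(-c2cc(/C=C/C(=O)c3ccc(N)cc3)[nH]n2)cc(OC)c1OC` — 15%
- compound 2 `COc1ccc(-c2cc(/C=C/C(=O)c3ccc(OC)c(OC)c3)[nH]n2)cc1` — 15%

In a functional assay on NCI/ADR-RES cells (Homo sapiens) for cytotoxicity, read by sulforhodamine B assay, with a stated time of 48 h, tested at 10 uM (a higher number here means a weaker effect of the compound at the concentration tested, a lower number a stronger effect), compound 1 gives 15%. Compound 2 gives 15% in this assay, so compound 1 stands level with compound 2, within the scatter. Going by the values given here, no single-change pair between measured compounds is available to calibrate the next step.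

Compound 3 `COc1cc(-c2cc(/C=C/C(=O)c3ccc(Cl)c(Cl)c3)[nH]n2)cc(OC)c1OC` differs from compound 1 by 3,4-dichlorophenyl in place of 4-aminophenyl on a carbonyl carbon. With no measured step of this kind in the series, a small shift is expected, if any, with the expected step of a number 5 percentage points higher from compound 1 to compound 3 (within the scatter) read as none beyond the scatter. Compound 3 is estimated at 20%, with a range from 5% to 50%.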

Compound 3, a percentage reported as activity, at one concentration (the size of the read-out at that concentration, not a potency): 51%
Estimate against measurement, compound 3: 31 percentage points below; the whole stated range lies below it.
By their numbers in this assay, from the lowest: compounds 1 and 2 (each within the scatter of the next); then compound 3.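

In this assay, 3,4-dichlorophenyl in place of 4-aminophenyl on a carbonyl carbon gives a number 36 percentage points higher from compound 1 to compound 3 (beyond the scatter) at the concentration tested. This first single-change step shows that the read-out responds to the group at this position, with 4-aminophenyl giving the stronger effect of the two. Nothing available explains the size of this step. From the compounds shown here alone, the change removes the amine and adds both chlorines at once, so which part carries the step stays open. An unsubstituted phenyl or a 4-hydroxyphenyl at this position would help separate the two.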